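This account rests on a few compounds, and the source may have more. Where it says the series, first, only, none or still open, it means among the compounds named here.

Notes on the series in an assay on HEK293 cells for displacement of a labelled ligand from NPC1-like intracellular cholesterol transporter 1 (Homo sapiens); a lower number here means a stronger inhibitor, a higher number a weaker inhibitor. Of the compounds shown here, three have been measured. Compound 1 `CC(C)(C)c1ccc(C(=O)N2CCC3(CC2)C(=O)N(CC(=O)NCCCCCNS(C)(=O)=O)CN3c2ccccc2)cc1` gives 5500 nM in this assay. Compound 2 `CC1(C)CC(OC(=O)CN2CN(c3ccccc3)C3(CCN(C(=O)c4ccc(C(C)(C)C)cc4)CC3)C2=O)CC(C)(C)N1` gives 1300 nM. Compound 3 `CCOC(=O)C1CCN(C(=O)CN2CN(c3ccccc3)C3(CCN(C(=O)c4ccc(C(C)(C)C)cc4)CC3)C2=O)CC1` gives 3100 nM, which places compound 3 second highest of the three numbers: its nearest neighbour is compound 1, with a 1.8-fold lower number from compound 1 to compound 3 (0.25 log units; within the scatter), and its furthest is compound 2, with a 2.4-fold higher number from compound 2 to compound 3 (0.38 log units; beyond the scatter). The remaining measured step, a 4.2-fold lower number from compound 1 to compound 2 (0.63 log units; beyond the scatter), is the largest seen so far.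

Compound 4 `CC(C)(C)c1ccc(C(=O)N2CCC3(CC2)C(=O)N(CC(=O)NCCCCCO)CN3c2ccccc2)cc1` has not been measured. It differs from compound 3 in one place: (5-hydroxypentyl)amino in place of 4-(ethoxycarbonyl)piperidin-1-yl on a carbonyl carbon. The measured steps that bear on this change are those that exchange the group on the same carbonyl carbon. The group entering in compound 4 is an amino-linked pentyl chain of the same kind as the (5-(methanesulfonamido)pentyl)amino group of compound 1, and a 1.8-fold lower number from compound 1 to compound 3 (0.25 log units; within the scatter) was within the scatter. The step of a 2.4-fold higher number from compound 2 to compound 3 (0.38 log units; beyond the scatter) went the other way and was beyond the scatter, but the group of compound 2 is of a different kind and gives less guidance. A step back toward the number of compound 1 is therefore expected, most likely within the scatter, namely a 1.5-fold higher number from compound 3 to compound 4 (0.16 log units; within the scatter). For compound 4 the estimate in this assay is 4500 nM, with a range from 2000 nM to 10000 nM.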

Compound 4, half-maximal inhibitory concentration: 9400 nM
Beside the measured number, compound 4's estimate is 2.1-fold (0.32 log units) below it, within the range that was stated.
By their numbers in this assay, from the lowest: compound 2; then compounds 3, 1 and 4 (each within the scatter of the next, the first and the last beyond it).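

In this assay, replacing the 4-(ethoxycarbonyl)piperidin-1-yl group on this carbonyl carbon with a pentyl chain can now produce a step beyond the scatter (a 3.0-fold higher number from compound 3 to compound 4 (0.48 log units; beyond the scatter)), whereas the corresponding step between compound 1 and compound 3 stayed within it. The end of the chain has not yet been shown to matter: hydroxy in place of methanesulfonamido gives only a step within the scatter (a 1.7-fold higher number from compound 1 to compound 4 (0.23 log units; within the scatter)), so these two chains cannot be told apart here. Among these compounds, the widest gap on this carbonyl carbon is now the step beyond the scatter to the (2,2,6,6-tetramethylpiperidin-4-yl)oxy group (a 7.2-fold higher number from compound 2 to compound 4 (0.86 log units; beyond the scatter)), and compound 2 is the only compound whose number lies beyond the scatter of both pentyl compounds, while compound 3 lies beyond that of compound 4 but not of compound 1.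

Going by these compounds, it remains open whether a primary amine or a carboxylic acid at the chain end, or a longer or shorter chain, would move the number away from that of the two pentyl compounds. Nothing available here accounts for any of these steps.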